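Trifluoromethyl for dimethylamino on the aryl amide cap

The compounds below may be only part of what the source reports. "The series", "measured", "known", "first", "only" and "open" are said of these compounds alone.

Compound 1 `CN(C)c1ccc(C(=O)N[C@@H](CCCCCC(=O)NO)C(=O)NCc2ccccc2)cc1` carries a dimethylamino group on the benzamide ring. In a functional assay on MM96L cells (Homo sapiens) for antiproliferative activity (a lower number here means a stronger inhibitor, a higher number a weaker inhibitor), compound 1 gives 1600 nM, the second highest of the three numbers recorded. For the measured compounds named here, its mirror-image partner, compound 2 `CN(C)c1ccc(C(=O)N[C@H](CCCCCC(=O)NO)C(=O)NCc2ccccc2)cc1`, gives 160 nM in this assay, and a 10-fold lower number from compound 1 to compound 2 (1.00 log units; beyond the scatter); the two share every atom and bond, so the fact that compounds 1 and 2 differ only in the configuration as drawn is the only difference behind that step. Compound 3 `O=C(CCCCCC(NC(=O)c1cccnc1)C(=O)NCc1ccccc1)NO`, which bears a pyridine carboxamide instead of the substituted benzamide and is drawn without a defined configuration, gives 9500 nM in this assay, a higher number than compound 1.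

Compound 4 `O=C(CCCCC[C@H](NC(=O)c1ccc(C(F)(F)F)cc1)C(=O)NCc1ccccc1)NO` keeps the configuration of compound 1 and changes only the cap: trifluoromethyl in place of dimethylamino on an aromatic carbon. Going by the values given here, no measured step here touches that position directly; the stereo step from compound 1 to compound 2 says nothing about the aryl substituent, and compound 3 changes the whole ring rather than one group. With no guidance from the measured steps, compound 4 is expected to stay close to compound 1 in this assay, a 1.1-fold lower number from compound 1 to compound 4 (0.03 log units; within the scatter), with no step beyond the scatter expected in either direction. The estimate for compound 4 in this assay is therefore 1500 nM, within a range from 400 nM to 6000 nM.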

Compound 4, half-maximal inhibitory concentration: 660 nM
Beside the measured number, compound 4's estimate is 2.3-fold (0.36 log units) above it; the range from low to high includes it.
By their numbers in this assay, from the lowest: compound 2; then compound 4; then compound 1; then compound 3.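

In this assay, putting trifluoromethyl in place of dimethylamino on an aromatic carbon, para to a large group, gives a 2.4-fold lower number from compound 1 to compound 4 (0.38 log units; beyond the scatter). For the compounds shown here, this is the first single-group change at this place: the earlier steps offered only a change of configuration and the swap of a whole ring, whereas this one shows that the substituent alone moves the number modestly and that dimethylamino, with its nitrogen and its one hydrogen-bond acceptor, can leave without the number rising. Nothing measured here accounts for why the number falls with this exchange.

The compounds shown leave open whether the configuration drawn in compound 2 would bring a further fall with trifluoromethyl on the ring, since the configuration step has been read only with dimethylamino in place. Going by these compounds alone, with only two groups compared at this place, no trend can be drawn, and it remains open where a chlorine, a methoxy group, a primary amine or a plain hydrogen on that carbon would stand relative to them.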